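A few compounds are considered here, and "the series" means these few. Any claim that something is new, unique, unknown or untested is made for them only; others in the source may bear on it.

Compound 1 `CCCNC(=O)COc1ccc2cc(C(O)(C(F)(F)F)C(F)(F)F)c(O)cc2c1`: in an assay on isolated protein for inhibition of tyrosine-protein phosphatase non-receptor type 13 (Homo sapiens), read by spectrophotometry (a lower number here means a stronger inhibitor, a higher number a weaker inhibitor), compound 1 gives > 20000 nM, which is a limit of the assay.
Compound 2 `O=C(COc1ccc2cc(C(O)(C(F)(F)F)C(F)(F)F)c(O)cc2c1)NCc1ccccc1`: compound 2 gives > 20000 nM, also a limit.
Compound 3 `O=C(COc1ccc2cc(C(O)(C(F)(F)F)C(F)(F)F)c(O)cc2c1)NCc1ccc(F)cc1`: compound 3 gives > 20000 nM, again a limit.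

Compound 1 therefore stands at the limit, the point where every value shown sits (the limit of > 20000 nM in this assay, at which 3 of the 3 values shown sit). Compound 4 `Oc1cc2ccccc2cc1C(O)(C(F)(F)F)C(F)(F)F` differs from compound 1 by hydrogen in place of (propylcarbamoyl)methoxy on an aromatic carbon. The measured steps, a step that the two limits leave unreadable from compound 1 to compound 2, a step that the two limits leave unreadable from compound 1 to compound 3 and a step that the two limits leave unreadable from compound 2 to compound 3, all run between limits, so none has a readable size, and none of them touches the group that is removed here. Going by the values given here, no measured step bears on this change. Compound 4 is therefore expected to give roughly 30000 nM, estimated to lie between 8000 nM and 100000 nM, most likely again as a limit. The step from compound 1 to compound 4 is estimated as a step that the limit leaves unreadable from compound 1 to compound 4.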

Compound 4, half-maximal inhibitory concentration: 128000 nM
The estimate for compound 4 lay 4.3-fold (0.63 log units) below the measured number; measured number above the stated range.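

No new step can be read: compound 4 has a measured number, but compound 1 has only a limit of the assay. Going by these compounds, whether the (propylcarbamoyl)methoxy group strengthens or weakens inhibition therefore stays open.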